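A few compounds are considered here, and "the series" means these few. Any claim that something is new, unique, unknown or untested is made for them only; others in the source may bear on it.

Compound 1 `CCCCCCC#Cc1c(CCCCCC)oc2nc(=O)n(Cc3cn(-c4ccc(Cl)cc4)nn3)cc12` gives in a functional assay on HepG2 cells (Homo sapiens) for antiproliferative activity, read by MTT assay, with a stated time of 72 h (a higher number here means a weaker inhibitor, a lower number a stronger inhibitor), only a limit, > 100000 nM.
Compound 2 `CCCCCCC#Cc1c(CCCCCC)oc2nc(=O)n(Cc3cn(Cc4ccccc4)nn3)cc12` gives in this assay 25800 nM.
Compound 3 `O=c1nc2oc(C3CC3)cc2cn1Cc1cn(-c2ccc(Cl)cc2)nn1` gives in this assay only a limit, > 100000 nM.

The change benzyl in place of 4-chlorophenyl on an aromatic nitrogen produced the step of an at least 3.8-fold lower number from compound 1 to compound 2 (0.58 log units; beyond the scatter), and this step is known only as a bound because of the limit of > 100000 nM in this assay, at which 2 of the 3 values shown sit. Compound 3 shares with compound 1 the 4-chlorophenyl on the triazole but has a different core; the difference between the two cores is not broken down here. Compound 4 `O=c1nc2oc(C3CC3)cc2cn1Cc1cn(Cc2ccccc2)nn1` carries the same change on the core of compound 3: benzyl in place of 4-chlorophenyl on an aromatic nitrogen. For compound 4 the step is expected to be an at least 1.6-fold lower number from compound 3 to compound 4 (0.22 log units; that floor lies within the scatter), resting on the step of an at least 3.8-fold lower number from compound 1 to compound 2 (0.58 log units; beyond the scatter) seen with the other core. Since compound 3 gives only a limit, this expectation is loose, and compound 4 is estimated at 60000 nM, between 15000 nM and 200000 nM.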

Compound 4, half-maximal inhibitory concentration: 49100 nM
Compound 4: the middle estimate sits 1.2-fold (0.09 log units) above what was measured, and the stated range covers the measured number.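

In this assay, benzyl in place of 4-chlorophenyl gives an at least 2.0-fold lower number from compound 3 to compound 4 (0.30 log units; that floor lies within the scatter), which fits the direction seen on the core of compound 1, although this floor alone does not clear the usual scatter. Whether the change has the same size on both cores cannot be decided: the same change on two cores in this assay, an at least 3.8-fold lower number (0.58 log units; beyond the scatter) from compound 1 to compound 2 and an at least 2.0-fold lower number (0.30 log units; that floor lies within the scatter) from compound 3 to compound 4; the limit leaves it open whether they differ. From the compounds shown here alone, both steps are only floors, and their true sizes stay unknown, because each starts from a compound that gives only a limit: the limit of > 100000 nM in this assay, at which 2 of the 4 values shown sit.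

Going by these compounds, neither core has a 4-chlorophenyl compound with an exact number, so the full size of the change remains open on both. Also open, on these data alone, is how a 4-chlorobenzyl or a phenethyl on that same aromatic nitrogen would compare with benzyl.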